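The source may hold more compounds than are shown below. What is called first, only, known or untested is meant among the compounds shown, and "the series" means these compounds.

Measured compounds:
compound 1, `COc1ccc2cc(-c3cccc(-c4cccnc4)c3)ccc2c1`: 3%
compound 2, `Oc1ccc2cc(-c3cccc(-c4cccnc4)c3)ccc2c1`: 0%

In an assay for inhibition of steroid 17-alpha-hydroxylase/17,20 lyase (Homo sapiens), tested at 0.2 uM (a lower number here means a weaker effect, a higher number a stronger effect of the compound at the concentration tested), compound 1 gives 3%, the higher of the two numbers, while compound 2 gives 0%; the two lie within the scatter of each other, as the step of a number 3 percentage points lower from compound 1 to compound 2 (within the scatter) shows, where hydrogen stands in place of methyl on an oxygen on an aromatic ring. Both compounds therefore show little effect at the concentration tested.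

Compound 3, `COc1ccc2cc(-c3cccc(Cn4ccnc4)c3)ccc2c1`, has not yet been measured in this assay. It differs from compound 1 in one place: (1H-imidazol-1-yl)methyl in place of pyridin-3-yl on an aromatic carbon. Among the measured compounds shown here, the single measured step concerns an oxygen on an aromatic ring of the shared core, not the place where this change occurs, so no measured step bears on the exchange of pyridin-3-yl for (1H-imidazol-1-yl)methyl. With compound 1 near the bottom of the scale and no comparison to build on, compound 3 is expected to stay near compound 1, with the step of a number 9 percentage points higher from compound 1 to compound 3 (within the scatter) estimated and wide uncertainty allowed. The estimate for compound 3 is 12%, between 0% and 45%.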

Compound 3, a percentage reported as inhibition, at one concentration (the size of the read-out at that concentration, not a potency): 0%
Estimate against measurement, compound 3: 12 percentage points above; the range from low to high includes it.
By their numbers in this assay, from the lowest: compounds 2, 3 and 1 (each within the scatter of the next).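

The second place changed in this series is the aromatic carbon meta to a large group, and in this assay the exchange of pyridin-3-yl for (1H-imidazol-1-yl)methyl gives a number 3 percentage points lower from compound 1 to compound 3 (within the scatter) on the methoxy-bearing core. A six-membered aromatic ring with 1 hetero atom and a five-membered aromatic ring with 2 hetero atoms on a methyl link, with 1 and 2 hydrogen-bond acceptors, thus leave the read-out near the bottom of the scale at the concentration tested, so this change, like the change on the oxygen, separates nothing within the scatter. No independent measurement is available that would explain this result.

From the compounds shown here alone, with both compared groups near the bottom of the scale, it stays open whether this position can influence the read-out at all, or whether the shared core holds it there whatever stands on this carbon. Nor do the compounds shown tell what an imidazol-1-yl group attached directly to the ring, a longer chain ending in imidazole, an amine or a carboxylic acid would do at this place.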